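Chloro in place of hydrogen: expectation for compound 4

The source may report more compounds than this note shows. Statements on the series, on what has been measured and on what is new or still open speak of the compounds shown alone.

Measured so far:
compound 1 `Cc1ccc(-c2csc(N/N=C/c3cccs3)n2)cc1` — 79.6%
compound 2 `Clc1ccc(/C=N/Nc2nc(-c3ccccc3)cs2)c(Cl)c1` — 78.1%
compound 3 `COC(=O)c1cc(-c2csc(N/N=C/c3cccs3)n2)ccc1OCc1ccccc1` — 79.6%

Of the compounds shown here, three of the shared core have been read in a functional assay, read by spectrophotometry, with a stated time of 15 min, tested at 20 ug/mL; a lower number here means a weaker effect, a higher number a stronger effect of the compound at the concentration tested. Compound 1 gives 79.6%, compound 3 gives 79.6% and compound 2 gives 78.1%. Compound 2 holds the lowest of the three numbers, yet its gap to compound 1 and its gap to compound 3 both lie within the scatter, so the three compounds cannot be ordered on these data. Among the measured compounds shown here, no pair of measured compounds differs in only one place, so the weight of any single change is unknown.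

Compound 4 `Clc1ccc(-c2csc(N/N=C/c3ccc(Cl)cc3Cl)n2)cc1` differs from compound 2 in one place: chloro in place of hydrogen on an aromatic carbon. Cut one bond further out, the difference reads phenyl to 4-chlorophenyl. Without a measured step of this kind, no direction can be drawn from the data, and the step is expected to be a number 0.1 percentage points lower from compound 2 to compound 4 (within the scatter), staying within the scatter. Compound 4 is expected to give about 78% in this assay, between 65% and 88%.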

Compound 4, a percentage reported as inhibition, at one concentration (the size of the read-out at that concentration, not a potency): 76%
The estimate for compound 4 lay 2 percentage points above the measured number; the measured number falls inside the stated range.
By their numbers in this assay, from the lowest: compounds 4, 2, 1 and 3 (each within the scatter of the next).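

In this assay, the series now has its first step in one place, phenyl to 4-chlorophenyl, and it reads a number 2.1 percentage points lower from compound 2 to compound 4 (within the scatter) and so lies within the scatter. At this position, para to a large group, the added chloro therefore leaves compound 2 and compound 4 indistinguishable at the one concentration tested, which says nothing about potency. Nothing measured here speaks to the reason for this result.

A single substituent says little about this position as a whole: an amine, a carboxylic acid or a methoxy group in the place of the chloro could still separate from compound 2. On these data alone, whether chloro in place of hydrogen gives a similar step on other members also remains open.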